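Removing the methoxy in a hepatoma cytotoxicity series

The source may hold more compounds than are shown below. What is called first, only, known or untested is meant among the compounds shown, and "the series" means these compounds.

Compound 1 `COc1ccc(-n2ccc(=O)c(C(=O)Nc3ccc(Oc4ccnc5[nH]ccc45)cc3)n2)cc1` gives 50800 nM in a functional assay on HepG2 cells (Homo sapiens) for cytotoxicity, read by MTT assay, with a stated time of 72 h (a higher number here means a weaker inhibitor, a lower number a stronger inhibitor), and compound 2 `O=C(Nc1ccc(Oc2ccnc3[nH]ccc23)cc1)c1nn(-c2ccc(Br)cc2)ccc1=O` gives 4280 nM. For compound 3 `COc1ccc(-n2ccc(=O)c(C(=O)Nc3ccc(Oc4ccnc5[nH]ccc45)c(F)c3)n2)cc1` this assay reports only a limit, > 60000 nM. Compound 4 `O=C(Nc1ccc(Oc2ccnc3[nH]ccc23)c(F)c1)c1nn(-c2ccccc2)ccc1=O` differs from compound 3 by hydrogen in place of methoxy on an aromatic carbon. Among the compounds with values here, two measured steps bear on this. The step of a 12-fold lower number from compound 1 to compound 2 (1.07 log units; beyond the scatter) shows that exchanging the methoxy at this position can move the number a great deal, whereas an at least 1.1-fold higher number from compound 1 to compound 3 (0.07 log units; that floor lies within the scatter) lies within the scatter. Hydrogen is a far smaller replacement than bromo, so a modest step toward a lower number is expected. Compound 4 is estimated at 35000 nM, a step of an at least 1.7-fold lower number from compound 3 to compound 4 (0.23 log units; that floor lies within the scatter). The estimate for compound 4 is expected to fall between 12000 nM and 100000 nM.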

Compound 4, half-maximal inhibitory concentration: 24900 nM
For compound 4 the middle estimate is 1.4-fold (0.15 log units) above the measured one, within the range that was stated.
By their numbers in this assay, from the lowest: compound 2; then compound 4; then compound 1. At a limit, above all of these: compound 3.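

In this assay, the change from 4-methoxyphenyl to phenyl gives an at least 2.4-fold lower number from compound 3 to compound 4 (0.38 log units; beyond the scatter). Removing the methoxy with no heavy atom entering in its place is thus enough to lower the number, whereas the earlier compounds had shown such a drop only with bromo in its place. The true size of this step remains unknown, since it starts from a limit: the limit of > 60000 nM in this assay, at which 1 of the 4 values shown sits.

On these data alone, it remains open whether the same change would lower the number in the core of compound 1, which lacks the fluoro. As far as these compounds go, it is also open how an amine or a carboxylic acid at this position would compare.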